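The source may report more compounds than this note shows. Statements on the series, on what has been measured and on what is new or still open speak of the compounds shown alone.

Measured in an ADME assay on L6 cells (Rattus norvegicus) for cytotoxicity, read by resazurin assay, with a stated time of 72 h; a higher number here means a weaker inhibitor, a lower number a stronger inhibitor:
- compound 1 `OC(c1ccc(Cl)cc1)(c1ccc(C(F)(F)F)cc1)c1cncnc1`: 66800 nM
- compound 2 `OC(c1ccc(Cl)cc1)(c1ccc(C(F)(F)F)cc1)c1cccnc1`: 56400 nM
- compound 3 `COc1ccc(C(O)(c2ccc(Cl)cc2)c2cccnc2)cc1`: 68100 nM

In this assay, compound 2 at 56400 nM lies within the scatter of both other measured compounds. The next compound to be measured, compound 4 `N#Cc1ccc(C(O)(c2ccc(C(F)(F)F)cc2)c2cccnc2)cc1`, differs from compound 2 by cyano in place of chloro on an aromatic carbon.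

Among the compounds with values here, no measured compound carries cyano, and no measured step changes the chloro group, so the evidence is indirect. Within the data shown here, the closest precedent is methoxy in place of trifluoromethyl on an aromatic carbon, a 1.2-fold higher number from compound 2 to compound 3 (0.08 log units; within the scatter). The other measured step, pyridin-3-yl in place of pyrimidin-5-yl, is a 1.2-fold lower number from compound 1 to compound 2 (0.07 log units; within the scatter). Both stay within the scatter, and neither shows a change that moves the read-out in a clear direction. The same therefore is expected of the new change in this assay, with no direction favoured and no shift beyond the scatter. Among the measured compounds shown here, the step expected is a 1.1-fold higher number from compound 2 to compound 4 (0.03 log units; within the scatter), though with only two steps to go on, the range is kept wide. The estimate for compound 4 is 60000 nM, with an expected range from 30000 nM to 120000 nM.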

Compound 4, half-maximal inhibitory concentration: 76500 nM
Compound 4: middle estimate off by 1.3-fold (0.11 log units), on the low side, within the range that was stated.
By their numbers in this assay, from the lowest: compounds 2, 1, 3 and 4 (each within the scatter of the next).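

In this assay, within the data shown here, the 4-chlorophenyl to 4-cyanophenyl exchange gives the first reading at this position, a 1.4-fold higher number from compound 2 to compound 4 (0.13 log units; within the scatter): cyano, with 2 heavy atoms and 1 hydrogen-bond acceptor, stands where chloro has 1 heavy atom and no acceptor, and the read-out stays within the scatter. With this step, single-place changes at three separate places in the series, the pyrimidin-5-yl group, the trifluoromethyl group and now the chloro group, have all stayed within the scatter, and none of the compounds shown goes against this, so in these four compounds no place yet stands out as one where the read-out responds. Nothing available bears on why this exchange leaves the number within the scatter.

Whether a quite different group at this position, such as an amine, a carboxylic acid or a longer chain, would carry the read-out beyond the scatter remains open, since cyano and chloro are the only two groups shown here. The oxygen on the saturated carbon is shared by all four compounds, so its part in the read-out cannot be told from them.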